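The compounds below may be only part of what the source reports. "The series", "measured", "known", "first", "only" and "open" are said of these compounds alone.

Working notes on the series. Compound 2 `Cc1cccc(C#CCOc2ccccc2)n1` stands only at a limit: in a functional assay with metabotropic glutamate receptor 5 (Homo sapiens) as the target, read by FLIPR (a lower number here means a stronger inhibitor, a higher number a weaker inhibitor), compound 2 gives > 10000 nM, which is a limit of the assay and not a number. Compound 1 `COc1cccc(OCC#Cc2ncccc2C)c1` sits at the same kind of mark: in this assay compound 1 gives > 10000 nM, also a limit. Compound 3 `Cc1cccc(C#CCOc2ccccc2Cl)n1` sits at another mark: in this assay compound 3 gives > 3000 nM, again a limit. Every value shown so far is therefore a limit, as the limit of > 10000 nM in this assay, at which 2 of the 3 values shown sit, and the limit of > 3000 nM in this assay, at which 1 of the 3 values shown sits, record. Among the compounds with values here, the single measured step between neighbours, a step that the two limits leave unreadable from compound 2 to compound 3, cannot be sized because the limit of > 10000 nM in this assay, at which 2 of the 3 values shown sit, and the limit of > 3000 nM in this assay, at which 1 of the 3 values shown sits, cap both of its ends.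

Compound 4 `Cc1cccc(C#CCOc2cccc(Cl)c2)n1` has not been measured. It differs from compound 2 by chloro in place of hydrogen on an aromatic carbon. Within the data shown here, the only measured step of the same kind is the one from compound 2 to compound 3, and that step is unreadable, so no size or direction in this assay can be taken from it; the outcome may be a step in either direction or none beyond the scatter, and another limit is the most likely report. Compound 4 is therefore expected near 10000 nM, within 3000 nM to 30000 nM. The step this estimate implies is a number no higher from compound 2 to compound 4 (the limit leaves the size open), an expectation resting on nothing firmer than the limits.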

Compound 4, half-maximal inhibitory concentration: 101 nM
Beside the measured number, compound 4's estimate is 99-fold (2.00 log units) above it; measured number below the stated range.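

Within the data shown here, with chloro on an aromatic carbon, meta to a large group, this assay gives the first readable step, an at least 99-fold lower number from compound 2 to compound 4 (1.99 log units; beyond the scatter), which shows that this single change at this place can lift the shared core from a limit to a measured number. That step gives only a minimum for the size of the change, because its starting end is a limit: the limit of > 10000 nM in this assay, at which 2 of the 4 values shown sit. Compound 3 carries the same chloro at another place on the ring and gives > 3000 nM in this assay, a limit and not a number, so among the compounds shown, chloro brings a measured number only at the place it holds in compound 4.

As far as these compounds go, whether the effect belongs to chloro itself remains open, since no other group at this place, such as bromo, nitrile or trifluoromethyl, can be set against it. Also open, from the compounds shown here alone, is whether the same change would give a step of similar size on the core of compound 1, and how much of the step from compound 2 lies beyond its limit.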